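A longer chain on compound 1

The compounds below may be only part of what the source reports. "The series", "measured", "known", "first", "only" and "open" are said of these compounds alone.

Measured in a functional assay on SW1573 cells (Homo sapiens) for antiproliferative activity, read by sulforhodamine B assay, with a stated time of 48 h; on this read-out higher numbers stand for weaker inhibition of growth and lower numbers for stronger inhibition of growth:
Compound 1 `CCCCC(C#CC(=O)OC)O/C=C/C(=O)OC`: 240 nM
Compound 2 `CCC(C)C(C#CC(=O)OC)O/C=C/C(=O)OC`: 910 nM
Compound 3 `COC(=O)/C=C/OC(C#CC(=O)O)C(C)(C)C`: > 100000 nM (a limit of the assay)

Of the two true numbers in this assay, the lower belongs to compound 1, at 240 nM. Compound 2 is its nearest neighbour, and the step that separates them, sec-butyl in place of butyl, is a 3.8-fold higher number from compound 1 to compound 2 (0.58 log units; beyond the scatter). Compound 3 reads > 100000 nM, which is a limit of the assay and not a number.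

Compound 4 `CCCCCCCCCCC(C#CC(=O)OC)O/C=C/C(=O)OC` has not yet been measured. Its difference from compound 1 is hexyl in place of hydrogen on a saturated chain carbon, five bonds along the chain from an oxygen on an unsaturated carbon and a triple-bonded carbon. The change leaves the rest of the structure as it is and adds a hexyl group with no ring and no net charge.

Within the data shown here, only one measured step bears on this change, since it alone alters the same chain. That step is modest, and it does not test a longer straight chain, so the direction remains uncertain. Taking compound 2 at 910 nM as the guide, a modest rise in the number is expected, meaning somewhat weaker inhibition of growth. The expected step is a 2.5-fold higher number from compound 1 to compound 4 (0.40 log units; beyond the scatter). For compound 4 the estimated value is 600 nM, with an expected range from 150 nM to 3000 nM.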

Compound 4, concentration for 50% growth inhibition: 2000 nM
Beside the measured number, compound 4's estimate is 3.3-fold (0.52 log units) below it; measured number inside the range.
By their numbers in this assay, from the lowest: compound 1; then compound 2; then compound 4. At a limit, above all of these: compound 3.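

In this assay, the hexyl extension weakens growth inhibition, with an 8.3-fold higher number from compound 1 to compound 4 (0.92 log units; beyond the scatter), so this position on the saturated chain does not reward simple lengthening of the chain. Until now, the only readable change to this chain was the switch to sec-butyl, with a 3.8-fold higher number from compound 1 to compound 2 (0.58 log units; beyond the scatter); the new step shows that adding straight chain, with no branch, also moves the number upward, so both changes made to the butyl chain of compound 1 weaken inhibition of growth, and compound 1 keeps the lowest true number among the compounds shown. Nothing measured here accounts for this loss of activity, and no available evidence bears on why the longer chain behaves as it does.

The compounds shown leave open how the number changes at chain lengths between those of compound 1 and compound 4, and whether a chain shorter than butyl, such as propyl or ethyl, would give stronger or weaker inhibition of growth. They also leave open what a phenyl ring, an amine or a hydroxyl group at the end of the chain would do to the number in this assay.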